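Ethoxy to butoxy from compound 3 to compound 4

The source may hold more compounds than are shown below. What is called first, only, known or untested is meant among the compounds shown, and "the series" means these compounds.

Measured values in a functional assay on Jurkat cells (Homo sapiens) for antiproliferative activity, read by MTT assay, with a stated time of 48 h; a higher number here means a weaker inhibitor, a lower number a stronger inhibitor
- compound 1 `COC(=O)/C=C/c1ccc2c(c1)C(=O)C(=O)N2Cc1ccc2ccccc2c1` gives 640 nM
- compound 2 `CCOC(=O)/C=C/c1ccc2c(c1)C(=O)C(=O)N2Cc1ccc(OC)cc1` gives 30 nM
- compound 3 `CCOC(=O)/C=C/c1ccc2c(c1)C(=O)C(=O)N2Cc1ccc(Br)cc1` gives 70 nM

Compound 3 at 70 nM holds the second highest of the three numbers, with compound 2 lower and compound 1 higher. Going from compound 3 to compound 4 `CCCCOC(=O)/C=C/c1ccc2c(c1)C(=O)C(=O)N2Cc1ccc(Br)cc1` the change is ethyl in place of hydrogen on a saturated chain carbon, two bonds along the chain from an oxygen next to a carbonyl group (read one bond further out, ethoxy to butoxy). Among the compounds with values here, no measured step isolates a change in this chain. Within the data shown here, the only measured step is a 2.3-fold higher number from compound 2 to compound 3 (0.37 log units; beyond the scatter) (bromo in place of methoxy on an aromatic carbon). That is a different change, so it serves only as a guide to size, and it gives no direction for this one. What is expected is a modest step toward a higher number in this assay (estimated as a 1.4-fold higher number from compound 3 to compound 4 (0.15 log units; within the scatter)), with little confidence in the direction. The estimated value for compound 4 is 100 nM (expected range 30 nM to 300 nM).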

Compound 4, half-maximal inhibitory concentration: 700 nM
For compound 4 the middle estimate is 7.0-fold (0.85 log units) below the measured one, outside the stated range (above it).
By their numbers in this assay, from the lowest: compound 2; then compound 3; then compounds 1 and 4 (each within the scatter of the next).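

In this assay, the ester chain is now the place of a single isolated change: with the bromo group held fixed, ethoxy to butoxy gives a 10-fold higher number from compound 3 to compound 4 (1.00 log units; beyond the scatter). That step is larger than a 2.3-fold higher number from compound 2 to compound 3 (0.37 log units; beyond the scatter), so on the compounds shown the ester chain weighs more than the swap of bromo for methoxy on the aromatic carbon, though this rests on one pair for each change. Nothing available accounts for the size of this step.

From the compounds shown here alone, whether a propoxy ester would fall between ethoxy and butoxy remains open, as does whether the step would hold with methoxy in place of bromo. Going by these compounds, how a carboxylic acid or an amide in place of the ester would read in this assay is also open.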